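The source may hold more compounds than are shown below. What is called first, only, known or untested is meant among the compounds shown, and "the series" means these compounds.

Measured in a functional assay on CUTLL1 cells (Homo sapiens) for inhibition, read by resazurin assay, with a stated time of 48 h, in the presence of a further agent that is not named here; on this read-out higher numbers stand for an effect only at larger amounts of compound and lower numbers for an effect already at smaller amounts:
- Compound 1 `Nc1ncc(-c2ccccn2)c(C2CC2)n1`: > 100000 nM (a limit)
- Compound 2 `Nc1ncc(-c2ccnc3ccccc23)c(C2CC2)n1`: > 100000 nM (a limit)
- Compound 3 `Nc1ncc(-c2ccnc(F)c2)c(C2CC2)n1`: > 100000 nM (a limit)

Within the data shown here, compound 3 gives no number in this assay, only a limit, and the whole series so far is the limit of > 100000 nM in this assay, at which 3 of the 3 values shown sit. The step to compound 4 `Nc1ncc(-c2ccnc(Cl)c2)c(C2CC2)n1` puts chloro in place of fluoro on an aromatic carbon, next to the ring nitrogen (chloro in place of fluoro on an aromatic carbon). Among the measured compounds shown here, no measured pair shows what a single change does. No step beyond the usual scatter is expected in this assay from compound 3, whose > 100000 nM is a limit, and a further limit is the likeliest report. The expected move is a number no higher from compound 3 to compound 4 (the limit leaves the size open), an estimate resting on limits alone. For compound 4 the estimated value is 100000 nM, with an expected range of 40000 nM to 200000 nM.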

Compound 4, half-maximal effective concentration: > 100000 nM
Compound 4: a limit, no number; the forecaster's own chance of this, stated with the estimate: 85%; the middle value sits exactly at the limit.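

Compound 3 and compound 4 both give only limits in this assay, so no step can be read between them. What any single change on the shared core does remains open, with the whole series at one limit: the limit of > 100000 nM in this assay, at which 4 of the 4 values shown sit.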